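A chloro swap on a thioester-linked chromone pair

The compounds below may be only part of what the source reports. "The series", "measured", "known", "first", "only" and "open" are said of these compounds alone.

Two compounds share one core with a dithiocarbamate side chain. In a functional assay on SW480 cells (Homo sapiens) for antiproliferative activity, read by MTT assay, with a stated time of 72 h (a higher number here means a weaker inhibitor, a lower number a stronger inhibitor), compound 1 `O=c1c(CSC(=S)N2CCOCC2)coc2cc(Cl)ccc12` gives 6200 nM and compound 2 `Cc1ccc2c(=O)c(CSC(=S)N3CCCC3)coc2c1` gives 5900 nM; the two numbers lie within the usual scatter of each other, so compound 2 stands alongside compound 1 rather than apart from it. Compound 3 `O=c1c(CSC(=S)N2CCCC2)coc2cc(Cl)ccc12` keeps the side chain of compound 2 and differs only by chloro in place of methyl on an aromatic carbon. Within the data shown here, no measured pair isolates this change. Because compound 1 already carries the chloro and shows 6200 nM, the step of a 1.0-fold higher number from compound 2 to compound 3 (0.01 log units; within the scatter) is expected to stay within the scatter, and compound 3 is estimated at 6000 nM, between 3000 nM and 12000 nM.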

Compound 3, half-maximal inhibitory concentration: 7800 nM
Compound 3: middle estimate off by 1.3-fold (0.11 log units), on the low side; measured number inside the range.
By their numbers in this assay, from the lowest: compounds 2, 1 and 3 (each within the scatter of the next).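

In this assay, among these compounds, the step of chloro in place of methyl on this aromatic carbon is a 1.3-fold higher number from compound 2 to compound 3 (0.12 log units; within the scatter) and gives the first direct reading of this change, which shows no separation between the two groups here. The first direct side-chain comparison, pyrrolidin-1-yl in place of morpholin-4-yl, is a 1.3-fold higher number from compound 1 to compound 3 (0.10 log units; within the scatter) and likewise shows no separation. No supporting data bear on either result. Still open, on these data alone, is whether a larger or more different group on this carbon, such as methoxy or a carboxylic acid, would separate from chloro and methyl. As far as these compounds go, whether a piperazine on the thiocarbonyl carbon would do so is also open.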